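The compounds below may be only part of what the source reports. "The series", "measured", "known", "first", "only" and "open" are said of these compounds alone.

Measured compounds in an ADME assay on MT4 cells (Homo sapiens) for cytotoxicity, read by MTT assay, with a stated time of 96 h; on this read-out lower numbers stand for higher toxicity in this test and higher numbers for lower toxicity in this test:
compound 1, `CC(=O)Nc1ccc(-c2nc3cc(C(F)(F)F)ccc3n2C)cc1`, 15000 nM
compound 2, `CC(=O)Nc1ccc(-c2nc3cc([N+](=O)[O-])ccc3[nH]2)cc1`, a limit of the assay, > 100000 nM
compound 3, `CC(=O)Nc1ccc(-c2nc3ccccc3[nH]2)cc1`, 100000 nM

Compound 3 gives the highest number of the two numbers shown; the nearest, compound 1, sits lower by a gap beyond the scatter. Compound 2 reports only a limit, (the limit of > 100000 nM in this assay, at which 1 of the 3 values shown sits).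

Compound 4, `CC(=O)Nc1ccc(-c2nc3cc(C(F)(F)F)ccc3[nH]2)cc1`, differs from compound 3 by trifluoromethyl in place of hydrogen on an aromatic carbon. For the measured compounds named here, the one measured step, a number no higher from compound 2 to compound 3 (the limit leaves the size open), concerns a nitro group, and its size stays open since compound 2 gives only a limit. Going by the values given here, no measured step covers entry of trifluoromethyl. Compound 1, carrying trifluoromethyl together with a further change, gives 15000 nM in this assay. On that slender basis a lower number is expected for compound 4: estimated step a 3.3-fold lower number from compound 3 to compound 4 (0.52 log units; beyond the scatter), estimated value 30000 nM, range 10000 nM to 100000 nM.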

Compound 4, half-maximal cytotoxic concentration: 19000 nM
The estimate for compound 4 lay 1.6-fold (0.20 log units) above the measured number; measured number inside the range.
By their numbers in this assay, from the lowest: compounds 1 and 4 (each within the scatter of the next); then compound 3.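

In this assay, trifluoromethyl alone accounts for a measured change at this position: a 5.3-fold lower number from compound 3 to compound 4 (0.72 log units; beyond the scatter), so the low number of compound 1 does not depend on its further change. The methyl on the aromatic nitrogen makes no difference that can be read: a 1.3-fold higher number from compound 1 to compound 4 (0.10 log units; within the scatter). Trifluoromethyl also separates from nitro, with an at least 5.2-fold lower number from compound 2 to compound 4 (0.72 log units; beyond the scatter), though compound 2 gives only a limit of the assay: the limit of > 100000 nM in this assay, at which 1 of the 4 values shown sits.

Going by these compounds, whether an amine, a nitrile or a carboxylic acid at this position would side with trifluoromethyl or with hydrogen stays open. Also open, on these data alone, is whether a longer chain on the aromatic nitrogen would matter more than methyl.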